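The source may hold more compounds than are shown below. What is called first, only, known or untested is meant among the compounds shown, and "the series" means these compounds.

Compound 1 `Cc1ccc(-c2nnc(NC(=O)/C=C/c3ccc(C(F)(F)F)cc3)s2)cc1` gives 1.61 ug/mL in a functional assay on A549 cells (Homo sapiens) for antiproliferative activity, read by MTT assay, with a stated time of 48 h; a higher number here means a weaker inhibitor, a lower number a stronger inhibitor.
Compound 2 `O=C(/C=C/c1ccc(F)cc1)Nc1nnc(-c2ccccc2)s1` gives 1.82 ug/mL in this assay.
Compound 3 `COc1ccc(-c2nnc(NC(=O)/C=C/c3ccc(C(F)(F)F)cc3)s2)cc1` gives 0.69 ug/mL in this assay.

Among these three, compound 3 has the lowest number and so is the strongest inhibitor here; its gaps to compound 1 and to compound 2 both lie beyond the usual scatter. For the measured compounds named here, the only single-point step among the measured compounds is a 2.3-fold lower number from compound 1 to compound 3 (0.37 log units; beyond the scatter), which concerns a different group and does not bear on the change now considered. Compound 4 `COc1ccc(-c2nnc(NC(=O)/C=C/c3ccc(F)cc3)s2)cc1` differs from compound 3 by fluoro in place of trifluoromethyl on an aromatic carbon. Going by the values given here, no measured pair isolates this change. Compound 2 also carries fluoro on that ring but lacks the methoxy, and compound 2 gives a higher number than compound 3; since the two structures differ in two places, the share belonging to the fluoro cannot be separated out. With nothing firmer to lean on, a modest weakening or no change beyond the scatter is expected. The estimated step is a 1.7-fold higher number from compound 3 to compound 4 (0.24 log units; within the scatter). For compound 4 the expected value is 1.2 ug/mL, with a range from 0.5 ug/mL to 3 ug/mL.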

Compound 4, half-maximal inhibitory concentration: 0.75 ug/mL
Beside the measured number, compound 4's estimate is 1.6-fold (0.20 log units) above it; the range from low to high includes it.
By their numbers in this assay, from the lowest: compounds 3 and 4 (each within the scatter of the next); then compounds 1 and 2 (each within the scatter of the next).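

In this assay, fluoro, with 1 heavy atom, takes the place of trifluoromethyl, with 4 heavy atoms, on this aromatic carbon para to a large group, and the result is a 1.1-fold higher number from compound 3 to compound 4 (0.04 log units; within the scatter), so the number does not separate these two groups here. With fluoro held in place, methoxy in place of hydrogen gives a 2.4-fold lower number from compound 2 to compound 4 (0.39 log units; beyond the scatter), a step in the same direction as a 2.3-fold lower number from compound 1 to compound 3 (0.37 log units; beyond the scatter), where methoxy replaced methyl. No data shown here give a reason for either result.

From the compounds shown here alone, whether an amine or a carboxylic acid at this position would also stay within the scatter of compound 3 remains open. Going by these compounds, it is also open whether fluoro and trifluoromethyl would match in the same way with methyl or hydrogen in place of the methoxy.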